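The source may hold more compounds than are shown below. What is called first, only, known or untested is meant among the compounds shown, and "the series" means these compounds.

Compound 1 `Cc1cc(C)c(-c2ncc[nH]2)cc1NC(=O)c1ccc(OCc2ccccn2)cc1`: 3.1
Compound 2 `Cc1cc(C)c(-c2ccccn2)cc1NC(=O)c1ccc(OCc2ccccn2)cc1`: > 3

In a physicochemical assay for lipophilicity (on this read-out higher numbers stand for higher lipophilicity and lower numbers for lower lipophilicity), compound 1 gives 3.1. Compound 2 sits at a limit of this assay, reported as > 3, so only a range is known for it. The move from compound 1 to compound 2 is therefore a step that the limit leaves unreadable from compound 1 to compound 2, and its size cannot be read off; the limit of > 3 in this assay, at which 1 of the 2 values shown sits, governs that pair.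

Compound 3 `Cc1cc(C)c(-c2cccc(N)n2)cc1NC(=O)c1ccc(OCc2ccccn2)cc1` differs from compound 2 by amino in place of hydrogen on an aromatic carbon, the new group standing on an aromatic carbon of a six-membered aromatic ring with one nitrogen, next to the ring nitrogen and meta to a large group. For the measured compounds named here, no measured step mirrors this change, and the one step recorded is itself unreadable. The estimated step from compound 2 to compound 3 is a number no higher from compound 2 to compound 3 (the limit leaves the size open), downward. Compound 3 is expected to give 3, between 2.3 and 3.7.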

Compound 3, distribution coefficient: > 3
Compound 3 gave a limit, no number; the forecaster's own chance of this, stated with the estimate: 30%; the middle value lies on the limit itself.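

In this assay compound 3 gives > 3 as a limit and not a number. For the compounds shown here, no step among compound 1, compound 2 and compound 3 can be read: the limit of > 3 in this assay, at which 2 of the 3 values shown sit. The compounds shown leave open how far the true values of compound 2 and compound 3 lie from each other and from that of compound 1.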